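Chloro for hydrogen on the aryl ring: series notes

The compounds below may be only part of what the source reports. "The series", "measured", "known", "first", "only" and "open" are said of these compounds alone.

Measured in a functional assay on A549 cells (Homo sapiens) for antiproliferative activity, read by MTT assay, with a stated time of 24 h; a higher number here means a weaker inhibitor, a lower number a stronger inhibitor:
compound 1 `COc1cc(-c2cc(C(=O)/C=C/c3ccc(Cl)cc3)nc3cc(-c4ccccc4)nn23)cc(OC)c1OC`: 23800 nM
compound 2 `COc1cc(-c2cc(C(=O)/C=C/c3ccccc3)nc3cc(-c4ccccc4)nn23)cc(OC)c1OC`: 18000 nM
compound 3 `COc1ccc(-c2cc(/C=C/C(=O)c3ccccc3)nc3cc(-c4ccccc4)nn23)cc1OC`: 10700 nM

Compound 2 and compound 1 share a core and differ by chloro in place of hydrogen on an aromatic carbon. This change made the step of a 1.3-fold higher number from compound 2 to compound 1 (0.12 log units; within the scatter). Compound 3 carries a different core; the difference between the two cores is not broken down here. Compound 3 gives the lowest of the three numbers, but its gap to compound 2 lies within the scatter, while its gap to compound 1 lies beyond it, so no order among compound 3 and compound 2 is claimed.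

Compound 4 `COc1ccc(-c2cc(/C=C/C(=O)c3ccc(Cl)cc3)nc3cc(-c4ccccc4)nn23)cc1OC` has not yet been measured in this assay. It differs from compound 3 by chloro in place of hydrogen on an aromatic carbon, the same change as that from compound 2 to compound 1, on the same kind of place. Among the compounds with values here, the only measured precedent for this change, the step from compound 2 to compound 1, lies within the scatter, so for compound 4 a step of about a 1.3-fold higher number from compound 3 to compound 4 (0.10 log units; within the scatter) is expected. On this basis compound 4 is estimated at 13500 nM, between 6500 nM and 30000 nM.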

Compound 4, half-maximal inhibitory concentration: 15400 nM
Compound 4: the middle estimate sits 1.1-fold (0.06 log units) below what was measured, within the range that was stated.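

In this assay, within the data shown here, chloro in place of hydrogen on the aromatic ring gives a 1.4-fold higher number from compound 3 to compound 4 (0.16 log units; within the scatter), so on this second core, as on the first, the change produces no step that can be told from the scatter. The two steps can be set side by side and do not differ: the same change on two cores in this assay, a 1.3-fold higher number (0.12 log units; within the scatter) from compound 2 to compound 1 and a 1.4-fold higher number (0.16 log units; within the scatter) from compound 3 to compound 4, 1.1-fold (0.04 log units) apart, within the scatter of two such steps. This shows only that, for these two pairs, the change carries from one core to the other without a detectable shift; it does not show that chloro truly raises the number, since each step is too small to be read alone, nor does it show that the agreement would hold on any further core.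

Still open, on these data alone, is whether another group in the same place, such as bromo, an amine or a carboxylic acid, would give a step beyond the scatter. Also open, as far as these compounds go, is whether chloro elsewhere on this ring, or on the other aromatic rings of these cores, would behave the same way.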